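Fluoro to Methoxy on the Benzyl Arm: Expecting Little Change

The compounds below may be only part of what the source reports. "The series", "measured", "known", "first", "only" and "open" are said of these compounds alone.

Two close relatives of one core have been tested in a functional assay on UACC-62 cells (Homo sapiens) for inhibition, read by sulforhodamine B assay, with a stated time of 48 h; on this read-out higher numbers stand for lower toxicity in this test and lower numbers for higher toxicity in this test. Compound 1 `COc1ccc(CNc2nc3cc(N)cc(N)c3nc2-c2ccccc2)cc1OC` gives 53700 nM, and compound 2 `Nc1cc(N)c2nc(-c3ccccc3)c(NCc3ccc(F)cc3)nc2c1` gives 56200 nM. Going by the values given here, compound 2 thus stands alongside compound 1, the only other measured compound, with a gap inside the usual scatter: a 1.0-fold higher number from compound 1 to compound 2 (0.02 log units; within the scatter).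

Compound 3 `COc1ccc(CNc2nc3cc(N)cc(N)c3nc2-c2ccccc2)cc1` is the next relative. Its difference from compound 2 is small: methoxy in place of fluoro on an aromatic carbon. Among the compounds with values here, only one measured step bears on this. It exchanged a 4-fluorophenyl for a 3,4-dimethoxyphenyl on the same saturated chain carbon, and it moved the read-out by a 1.0-fold higher number from compound 1 to compound 2 (0.02 log units; within the scatter), which is within the scatter. Compound 3 carries a single methoxy where compound 1 carries two and compound 2 carries fluorine, so it lies between those two in structure, and their numbers in this assay are indistinguishable.

The step from compound 2 to compound 3 is therefore expected to stay within the scatter, with no clear direction: a 1.0-fold lower number from compound 2 to compound 3 (0.01 log units; within the scatter). For compound 3 the estimate in this assay is 55000 nM, with a range from 27000 nM to 110000 nM.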

Compound 3, concentration lethal to 50% of the cells: 58900 nM
Estimate against measurement, compound 3: 1.1-fold (0.03 log units) below, within the range that was stated.
By their numbers in this assay, from the lowest: compounds 1, 2 and 3 (each within the scatter of the next).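

In this assay the earlier step swapped two features at once, while methoxy in place of fluoro on an aromatic carbon, para to a large group, is a single exchange and gives (a 1.0-fold higher number from compound 2 to compound 3 (0.02 log units; within the scatter)), so this one position can now be read directly. The second new comparison isolates a different single exchange, hydrogen in place of methoxy on an aromatic carbon, and it too stays inside the usual scatter (a 1.1-fold higher number from compound 1 to compound 3 (0.04 log units; within the scatter)), which means that neither of these exchanges on the benzyl arm separates the compounds in this test. No measurement is at hand that would explain this flat result or say what it reflects.

From the compounds shown here alone, all three compounds carry small neutral groups on this aromatic ring, so it remains open whether an amine or a carboxylic acid on the same carbon, which would introduce a charge-bearing group, would move the number beyond the scatter. Also open, going by these compounds, is whether the arm itself matters, for example whether a longer chain in place of the single carbon linking this ring to the shared core would shift the read-out.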